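The compounds below may be only part of what the source reports. "The series", "measured", "known", "first", "only" and "open" are said of these compounds alone.

Three carbamates on the shared core have been measured in an assay for inhibition of serine/threonine-protein kinase PAK 4 (Homo sapiens), read by FRET and Z'-LYTE, with a stated time of 60 min, tested at 0.5 uM, in the presence of a further agent that is not named here; on this read-out lower numbers stand for a weaker effect and higher numbers for a stronger effect at the one concentration tested: compound 1 `CC(C)COC(=O)N1CCN(C(=O)c2nc(Nc3cc(C4CC4)[nH]n3)c3cc(Cl)ccc3n2)C[C@H]1C` gives 0.8%, compound 2 `CC(OC(=O)N1CCN(C(=O)c2nc(Nc3cc(C4CC4)[nH]n3)c3cc(Cl)ccc3n2)C[C@H]1C)OC(=O)C(C)(C)C` gives -6.9%, and compound 3 `C[C@@H]1CN(C(=O)c2nc(Nc3cc(C4CC4)[nH]n3)c3cc(Cl)ccc3n2)CCN1C(=O)OCc1ccccc1` gives 4.4%. Compound 3 holds the highest number of the three, but only the gap to compound 2 is beyond the scatter; compound 1 sits within it. The two steps that vary the carbamate, a number 7.7 percentage points lower from compound 1 to compound 2 (within the scatter) and a number 3.6 percentage points higher from compound 1 to compound 3 (within the scatter), stay within the scatter, while a number 11.3 percentage points higher from compound 2 to compound 3 (beyond the scatter) is a modest change. All three numbers are close to zero at the concentration tested.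

Compound 4 `CCCCCOC(=O)N1CCN(C(=O)c2nc(Nc3cc(C4CC4)[nH]n3)c3cc(Cl)ccc3n2)C[C@H]1C` differs from compound 3 by butyl in place of phenyl on a saturated chain carbon bound to an oxygen next to a carbonyl group. Going by the values given here, the nearest precedent is the change at the same place from compound 1 to compound 3, which stayed within the scatter, so a change of chain in place of the phenyl is expected to move the read-out little if at all. The step expected in this assay is a number 1.9 percentage points lower from compound 3 to compound 4 (within the scatter), that is, none beyond the scatter. The number expected for compound 4 in this assay is 2.5%, with a range from -8% to 13%.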

Compound 4, a percentage reported as inhibition, at one concentration (the size of the read-out at that concentration, not a potency): -3.8%
Compound 4: the middle estimate sits 6.3 percentage points above what was measured; low and high end bracket the measured number.
By their numbers in this assay, from the lowest: compounds 2, 4, 1 and 3 (each within the scatter of the next, the first and the last beyond it).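

In this assay an open chain in place of the ring at this place makes no readable difference, with a number 8.2 percentage points lower from compound 3 to compound 4 (within the scatter) and with a number 4.6 percentage points lower from compound 1 to compound 4 (within the scatter) and a number 3.1 percentage points higher from compound 2 to compound 4 (within the scatter) as well. Going by these compounds alone, compound 4 therefore lies within the scatter of all three earlier carbamates, including both members of the one pair that lies beyond it (compound 2 and compound 3), so a phenyl ring on this saturated chain carbon is not needed for a number of this size. Nothing available bears on why these carbamates read alike.

Still open, from the compounds shown here alone, is whether any group on this oxygen moves the read-out clearly away from the numbers seen so far. A longer chain, or a chain carrying an amine or a carboxylic acid, would test this.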